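The compounds below may be only part of what the source reports. "The series", "measured", "known", "first", "only" and "open" are said of these compounds alone.

Compound 1: `CCCS(=O)(=O)Nc1ccc(F)c(C(=O)c2n[nH]c3ncc(-c4ccc(C)cc4)cc23)c1F`, 5.4%
Compound 2: `CCCS(=O)(=O)Nc1ccc(F)c(C(=O)c2n[nH]c3ncc(-c4ccc(C(C)C)cc4)cc23)c1F`, 17%
Compound 3: `CCCS(=O)(=O)Nc1ccc(F)c(C(=O)c2n[nH]c3ncc(-c4ccc(F)cc4C)cc23)c1F`, 14%

In an assay for binding affinity to dual specificity mitogen-activated protein kinase kinase 4 (Homo sapiens), read by KINOMEscan, tested at 100 nM (on this read-out lower numbers stand for a stronger effect and higher numbers for a weaker effect at the one concentration tested), compound 3 gives 14%. Among the three measured compounds compound 3 stands second highest; its nearest neighbour is compound 2, and a number 3 percentage points lower from compound 2 to compound 3 (within the scatter), while toward compound 1 the gap is a number 8.6 percentage points higher from compound 1 to compound 3 (within the scatter). Among the measured compounds shown here, the one change that does reach beyond the scatter is a number 11.6 percentage points higher from compound 1 to compound 2 (beyond the scatter).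

Compound 4, `CCCS(=O)(=O)Nc1ccc(F)c(C(=O)c2n[nH]c3ncc(-c4ccc(S(=O)(=O)NCC)cc4)cc23)c1F`, differs from compound 3 at the aryl group attached to the shared core: 4-(ethylsulfamoyl)phenyl in place of 4-fluoro-2-methylphenyl on an aromatic carbon

For the measured compounds named here, no measured step covers the entry of an ethylsulfamoyl group; the closest parallel is the growth of the para substituent in the step from compound 1 to compound 2, which raised the read-out modestly. The step from compound 3 to compound 4 is therefore expected to be small, and if anything upward in this assay, giving a number 8 percentage points higher from compound 3 to compound 4 (within the scatter). Compound 4 is estimated at 22%, within a range from 6% to 50%.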

Compound 4, a percentage reported as activity, at one concentration (the size of the read-out at that concentration, not a potency): 3%
For compound 4 the middle estimate is 19 percentage points above the measured one; the measured number lies below the stated range.
By their numbers in this assay, from the lowest: compounds 4, 1, 3 and 2 (each within the scatter of the next, the first and the last beyond it).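

In this assay this position takes the 4-(ethylsulfamoyl)phenyl group, the largest aryl group shown and the only one with a hydrogen-bond donor or acceptors, and the change gives a number 11 percentage points lower from compound 3 to compound 4 (beyond the scatter) and, against the isopropyl group, a number 14 percentage points lower from compound 2 to compound 4 (beyond the scatter) as the two steps that reach past the scatter. Growth of the para group therefore does not by itself raise the number, as the isopropyl step alone had suggested, and against the small methyl group the comparison gives only a number 2.4 percentage points lower from compound 1 to compound 4 (within the scatter) with no order between the two compounds. Nothing available here accounts for these steps.

The compounds shown leave open whether a longer chain on the sulfonamide nitrogen would keep the number this low. They also leave open whether a carboxylic acid, an amine or a methylsulfonyl group at the same place of the phenyl ring would behave like the ethylsulfamoyl group.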